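Stability of a sulfonated azetidinone after swapping the side-chain ring

This account rests on a few compounds, and the source may have more. Where it says the series, first, only, none or still open, it means among the compounds named here.

Measured so far:
compound 1 `CC(C)(O/N=C(\C(=O)N[C@@H]1C(=O)N(S(=O)(=O)O)[C@@H]1CN1CCNC1=O)c1csc(N)n1)C(=O)O` — > 1000 h
compound 2 `CC(C)(O/N=C(\C(=O)N[C@@H]1C(=O)N(S(=O)(=O)O)[C@@H]1Cn1cncn1)c1csc(N)n1)C(=O)O` — 233 h

In a physicochemical assay for metabolic stability, read by HPLC and mass spectrometry, in phosphate buffer, at 37 degrees C, at pH 7.4 (on this read-out higher numbers stand for a longer-lived compound and lower numbers for a shorter-lived compound), compound 1 sits at a limit of the assay, (the limit of > 1000 h in this assay, at which 1 of the 2 values shown sits), so its value is a limit and not a number. Within the data shown here, compound 2 gives 233 h in this assay, and the only measured step is an at least 4.2-fold lower number from compound 1 to compound 2 (0.63 log units; beyond the scatter). Compound 3 `CC(C)(O/N=C(\C(=O)N[C@@H]1C(=O)N(S(=O)(=O)O)[C@@H]1CN1C[C@H](CNC(=N)N)OC1=O)c1csc(N)n1)C(=O)O` is not yet measured; it differs from compound 1 by a group of 11 heavy atoms (5 carbon, 4 nitrogen, 2 oxygen; one five-membered non-aromatic ring with 2 hetero atoms) in place of a group of 6 heavy atoms (3 carbon, 2 nitrogen, 1 oxygen; one five-membered non-aromatic ring with 2 hetero atoms), on a saturated chain carbon bound to a saturated ring carbon. The measured step replaced the same group with an aromatic ring, whereas here a non-aromatic ring with 2 hetero atoms enters again, so a step no larger than that one, and possibly none beyond the scatter, is expected. Compound 3 is estimated at 800 h, with a range of 250 h to 3000 h. The expected step is therefore an at least 1.2-fold lower number from compound 1 to compound 3 (0.09 log units; that floor lies within the scatter).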

Compound 3, half-life: > 37 h
Compound 3: only a limit was reported (the forecaster's own chance of this, stated with the estimate: 40%); the middle value is on the limit's open side.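

In this assay compound 3 gives > 37 h, a limit and not a number, so its steps from compound 1 and compound 2 cannot be read. The compounds shown leave open where compound 3 stands relative to either compound.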